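Fluoro for methyl on the 4-methylphenyl group

The source may hold more compounds than are shown below. What is called first, only, known or untested is meant among the compounds shown, and "the series" means these compounds.

Results in a functional assay on SGC-7901 cells (Homo sapiens) for antiproliferative activity, read by MTT assay, with a stated time of 72 h (a higher number here means a weaker inhibitor, a lower number a stronger inhibitor), for the three measured compounds:
Compound 1 `COc1cc(-n2cnc3ccc(-c4cccc(C)c4)cc32)cc(OC)c1OC` gives 1240 nM
Compound 2 `COc1cc(-n2cnc3ccc(-c4cccc([N+](=O)[O-])c4)cc32)cc(OC)c1OC` gives 380 nM
Compound 3 `COc1cc(-n2cnc3ccc(-c4ccc(C)cc4)cc32)cc(OC)c1OC` gives 200 nM

Compound 3 stands well clear of compound 1, with a 6.2-fold lower number from compound 1 to compound 3 (0.79 log units; beyond the scatter) separating them. It cannot be told apart from compound 2, as a 1.9-fold lower number from compound 2 to compound 3 (0.28 log units; within the scatter) shows.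

Compound 4 `COc1cc(-n2cnc3ccc(-c4ccc(F)cc4)cc32)cc(OC)c1OC` carries fluoro in place of methyl on an aromatic carbon, para to a large group (fluoro in place of methyl on an aromatic carbon). This is the change from 4-methylphenyl to 4-fluorophenyl. For the measured compounds named here, no measured compound here carries fluoro, so the evidence is indirect. Going by the values given here, the nearest precedent is a 3.3-fold lower number from compound 1 to compound 2 (0.51 log units; beyond the scatter), where nitro replaces methyl on an aromatic carbon and the step is modest. That step starts from the 3-methylphenyl compound, however, and not from the 4-methylphenyl one. The step of a 6.2-fold lower number from compound 1 to compound 3 (0.79 log units; beyond the scatter) shows that moving the methyl alone changes the number by a modest amount, so a precedent from the other position transfers only loosely.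

In this assay a small shift towards a higher number is therefore expected, most likely within the scatter. The estimated step is a 1.4-fold higher number from compound 3 to compound 4 (0.15 log units; within the scatter) and no larger shift is expected. The expected value for compound 4 is 280 nM (estimated range 80 nM to 950 nM).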

Compound 4, half-maximal inhibitory concentration: 3500 nM
Beside the measured number, compound 4's estimate is 13-fold (1.10 log units) below it; the measured number lies above the stated range.
By their numbers in this assay, from the lowest: compounds 3 and 2 (each within the scatter of the next); then compound 1; then compound 4.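

In this assay, fluoro in place of methyl on an aromatic carbon, para to a large group, gives an 18-fold higher number from compound 3 to compound 4 (1.24 log units; beyond the scatter), the largest step among the four compounds, so this single-atom exchange on the 4-substituted phenyl group is far from neutral. The 4-substituted pattern does not carry activity by itself: the 4-fluorophenyl group falls behind both 3-substituted groups, with a 9.2-fold higher number from compound 2 to compound 4 (0.96 log units; beyond the scatter) and a 2.8-fold higher number from compound 1 to compound 4 (0.45 log units; beyond the scatter), which makes compound 4 the weakest of the four, whereas the 4-methylphenyl group of compound 3 has the lowest number of the four, though within the scatter of compound 2. The good value of compound 3 therefore depends on the methyl at this place as well as on the position, and nothing shown here accounts for the loss on going to fluoro.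

From the compounds shown here alone, whether methyl is specially favoured here or fluoro is specially poor remains open, since only these two groups can be compared at this place. An unsubstituted phenyl, or a chloro, methoxy, ethyl or amino group at the same carbon, would help to separate these two readings.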